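Moving the halogen on the hydroxyphenyl ring of compound 1

The source may report more compounds than this note shows. Statements on the series, on what has been measured and on what is new or still open speak of the compounds shown alone.

Going by the values given here, compound 1 `O=C(Nc1cc(C(F)(F)F)cc(C(F)(F)F)c1)c1cc(Br)ccc1O` stands lowest of the two numbers so far in a functional assay on KG-1 cells (Homo sapiens) for cytotoxicity, read by luminescence and CellTiter-Glo, with a stated time of 3 days (on this read-out higher numbers stand for weaker inhibition and lower numbers for stronger inhibition), where compound 1 gives 300 nM. Compound 2 `O=C(Nc1ccc(C(F)(F)F)cc1)c1cc(Br)ccc1O` gives 610 nM in this assay, a number beyond the scatter above that of compound 1. Compound 3 `O=C(Nc1cc(C(F)(F)F)cc(C(F)(F)F)c1)c1ccc(Cl)cc1O` is still unmeasured and differs from compound 1 by 4-chloro-2-hydroxyphenyl in place of 5-bromo-2-hydroxyphenyl on a carbonyl carbon. Among the compounds with values here, no measured pair shows this change, so the step is unsupported by data; a modest shift in this assay toward weaker inhibition is expected, near the edge of the scatter. Compound 3 is thus estimated at 500 nM, with a range of 150 nM to 1600 nM, and the expected step is a 1.7-fold higher number from compound 1 to compound 3 (0.22 log units; within the scatter).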

Compound 3, half-maximal inhibitory concentration: 620 nM
Estimate against measurement, compound 3: 1.2-fold (0.09 log units) below; the range from low to high includes it.
By their numbers in this assay, from the lowest: compound 1; then compounds 2 and 3 (each within the scatter of the next).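

With the rest of compound 1 unchanged, placing 4-chloro-2-hydroxyphenyl in place of 5-bromo-2-hydroxyphenyl on the carbonyl carbon gives a 2.1-fold higher number from compound 1 to compound 3 (0.32 log units; beyond the scatter) in this assay. Going by these compounds alone, this is the first sign that this part of the compound affects the number, though the halogen and its place change together in this single step. Nothing available explains the shift.

The compounds shown do not separate the effect of the halogen from that of its place. They also leave open what a methoxy group or an amine would give in the halogen's stead.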